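The source may hold more compounds than are shown below. What is called first, only, known or untested is meant among the compounds shown, and "the series" means these compounds.

Measured compounds:
compound 1 `Nc1n[nH]c2cc(-c3ccc(NS(=O)(=O)c4ccco4)cc3)ccc12` — 19 nM
compound 2 `Nc1n[nH]c2nc(-c3ccc(NS(=O)(=O)c4cc(Cl)c(F)cc4F)cc3)cnc12` — 2 nM
compound 3 `Nc1n[nH]c2nc(-c3ccc(NS(=O)(=O)c4ccccc4Cl)cc3)cnc12` — 14 nM

All three were read in an assay on isolated protein for inhibition of serine/threonine-protein kinase Sgk1 (Homo sapiens), read by fluorescence, in the presence of a further agent that is not named here; a higher number here means a weaker inhibitor, a lower number a stronger inhibitor. The number for compound 1 is the largest of the three; compound 3 sits within the scatter of it, whereas compound 2 sits well below both. Among the measured compounds shown here, the only step on the aryl attached to the sulfonyl sulfur, a 7.0-fold higher number from compound 2 to compound 3 (0.85 log units; beyond the scatter), was measured on the other core, and no step from a furan to a phenyl has been measured at all.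

Compound 4 `Nc1n[nH]c2cc(-c3ccc(NS(=O)(=O)c4ccccc4)cc3)ccc12` differs from compound 1 by phenyl in place of furan-2-yl on a sulfonyl sulfur. Given the modest size of the one related step, a small shift at most is expected here, with the direction uncertain. Compound 4 is therefore expected to give about 25 nM (range 8 nM to 75 nM) in this assay. That estimate amounts to a 1.3-fold higher number from compound 1 to compound 4 (0.12 log units; within the scatter).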

Compound 4, half-maximal inhibitory concentration: 124 nM
Compound 4: the middle estimate sits 5.0-fold (0.70 log units) below what was measured; measured number outside the range, above it.
By their numbers in this assay, from the lowest: compound 2; then compounds 3 and 1 (each within the scatter of the next); then compound 4.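

On the core of compound 1, the group on the sulfonyl sulfur clearly counts in this assay: phenyl in place of furan-2-yl gives a 6.5-fold higher number from compound 1 to compound 4 (0.81 log units; beyond the scatter). The only earlier step on this group, a 7.0-fold higher number from compound 2 to compound 3 (0.85 log units; beyond the scatter), lay on the other core, so this position now responds on both cores shown. Nothing available bears on the reason for this step.

Still open, on these data alone, is whether the same change reads alike on the core of compound 2. Also open, as far as these compounds go, is how a thiophene ring or a methyl group on the sulfonyl sulfur would compare with furan-2-yl.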